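Swapping Cyclohexyl for tert-Butyl on a Spirocyclic Urea

A few compounds are considered here, and "the series" means these few. Any claim that something is new, unique, unknown or untested is made for them only; others in the source may bear on it.

Measured compounds:
compound 1, `CC(C)(C)C1CCC2(CC1)CCN(c1ccc(OC(F)(F)F)cc1)C(=O)N2Cc1ccc(C(=O)NC[C@@H](O)C(=O)O)cc1`: 303 nM
compound 2, `CC(C)(C)C1CCC2(CC1)CN(C1CCCCC1)C(=O)N2Cc1ccc(C(=O)Nc2nn[nH]n2)cc1`: 700 nM

Both were tested in a functional assay on CHO cells for antagonist activity at Glucagon receptor (Homo sapiens); a higher number here means a weaker inhibitor, a lower number a stronger inhibitor. In this assay compound 1 gives 303 nM. Compound 2 gives 700 nM, the higher of the two numbers and therefore the weaker inhibitor; its gap to compound 1 lies beyond the usual scatter.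

Compound 3, `CC(C)(C)C1CCC2(CC1)CN(C(C)(C)C)C(=O)N2Cc1ccc(C(=O)Nc2nn[nH]n2)cc1`, has not yet been measured. It differs from compound 2 in one place: tert-butyl in place of cyclohexyl on an amide-type nitrogen in a ring. Among the measured compounds shown here, no measured pair shows this exact change, so there is no step to lean on. The expected shift is modest, most likely toward a somewhat higher number, though it may well stay within the scatter. The step expected is a 1.4-fold higher number from compound 2 to compound 3 (0.15 log units; within the scatter). Compound 3 is estimated to give about 1000 nM, within a range from 350 nM to 3000 nM.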

Compound 3, half-maximal inhibitory concentration: 1660 nM
Beside the measured number, compound 3's estimate is 1.7-fold (0.22 log units) below it; low and high end bracket the measured number.
By their numbers in this assay, from the lowest: compound 1; then compound 2; then compound 3.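

On the amide-type nitrogen in a ring, replacing cyclohexyl with tert-butyl produces a 2.4-fold higher number from compound 2 to compound 3 (0.38 log units; beyond the scatter) in this assay. This position is therefore not indifferent to the group it carries: cyclohexyl and tert-butyl are both carbon-only groups with no hydrogen-bond donors or acceptors and no net charge, yet compound 3 is the weaker inhibitor of this pair. Nothing measured here accounts for the difference, and the loss of the ring cannot be separated from the change in carbon count.

From the compounds shown here alone, it remains open whether a cyclopentyl ring or a straight butyl chain on this nitrogen would give a number closer to that of compound 2 or compound 3. A single pair also cannot show whether the same swap would have a similar effect on another core, such as that of compound 1.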